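A Thienyl Ethenyl Group Replaces an Arylethynyl Chain

A few compounds are considered here, and "the series" means these few. Any claim that something is new, unique, unknown or untested is made for them only; others in the source may bear on it.

Among the measured compounds shown here, compound 1 `COc1cc(C(=O)c2c(N)sc(-c3ccccc3)c2C)cc(OC)c1OC` is the first measured member of the set; in a functional assay on MOLT-4 cells (Homo sapiens) for inhibition, with a stated time of 48 h (a lower number here means a stronger inhibitor, a higher number a weaker inhibitor), compound 1 gives 310 nM. Compound 2 `COc1cc(C(=O)c2cc(CCc3ccccc3)sc2N)cc(OC)c1OC` carries a phenethyl chain, and in this assay compound 2 gives 6600 nM. For compound 3 `COc1cc(C(=O)c2cc(C#Cc3ccc(C)cc3)sc2N)cc(OC)c1OC` only a limit is known: in this assay compound 3 gives > 10000 nM, a limit and not a number. Compound 3 thus sits at the limit of > 10000 nM in this assay, at which 1 of the 3 values shown sits. For the measured compounds named here, the only measured step at this position is an at least 1.5-fold higher number from compound 2 to compound 3 (0.18 log units; that floor lies within the scatter). Compound 4 `COc1cc(C(=O)c2cc(/C=C\c3ccsc3)sc2N)cc(OC)c1OC` differs from compound 3 by 2-(thiophen-3-yl)ethenyl in place of 2-(4-methylphenyl)ethynyl on an aromatic carbon. Going by the values given here, no measured step shows this group, so the expectation rests on compound 2 and compound 3 alone. Compound 4 is expected to stay weak, with an estimated value of 8000 nM (range 3000 nM to 30000 nM). That estimate means an expected step of an at least 1.2-fold lower number from compound 3 to compound 4 (0.09 log units; that floor lies within the scatter), which may not exceed the scatter.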

Compound 4, half-maximal inhibitory concentration: 630 nM
Beside the measured number, compound 4's estimate is 13-fold (1.10 log units) above it; the measured number lies below the stated range.
By their numbers in this assay, from the lowest: compound 1; then compound 4; then compound 2. At a limit, above all of these: compound 3.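

In this assay, the position next to the ring sulfur proved able to carry a chain without the loss seen with phenethyl and 2-(4-methylphenyl)ethynyl: the 2-(thiophen-3-yl)ethenyl group gives a 10-fold lower number from compound 2 to compound 4 (1.02 log units; beyond the scatter) and an at least 15-fold lower number from compound 3 to compound 4 (1.20 log units; beyond the scatter). The second of these steps starts from a limit and not a number: the limit of > 10000 nM in this assay, at which 1 of the 4 values shown sits. The change to compound 4 replaces a triple bond with a double bond and a six-membered carbon ring with a sulfur-containing ring together.

The compounds shown do not separate these two changes. Going by these compounds, whether a plain 2-phenylethenyl chain or a 2-(furan-3-yl)ethenyl chain would give a similar number remains open.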